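The compounds below may be only part of what the source reports. "The series", "measured", "known", "first", "only" and "open" are said of these compounds alone.

Measured so far:
compound 1 `O=C(O)c1ccc2nc(CN3CCC[C@H](O[C@H](CO)c4cc(Cl)cc(Cl)c4)[C@@H]3c3ccccc3)[nH]c2c1` — 380 nM
compound 2 `Cc1cc(C(=O)O)ccc1CN1CCC[C@H](OC(c2cc(Cl)cc(Cl)c2)C(C)O)[C@@H]1c1ccccc1` — 5300 nM

In an assay on isolated protein for activation of cGMP-dependent protein kinase 1 (Homo sapiens), read by ADP-Glo, with stated times of 30 min and 2 h, in the presence of a further agent that is not named here (on this read-out higher numbers stand for an effect only at larger amounts of compound and lower numbers for an effect already at smaller amounts), compound 1 gives 380 nM, the lower of the two numbers, and compound 2 gives 5300 nM, a much higher number. Among the compounds with values here, the two structures differ in several places at once, so the pair on its own shows only that compound 1 acts at smaller amounts than compound 2.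

Compound 3 `O=C(O)c1ccc(CN2CCC[C@H](O[C@H](CO)c3cc(Cl)cc(Cl)c3)[C@@H]2c2ccccc2)c([N+](=O)[O-])c1` is not yet measured. It keeps the core of compound 1 and changes one part: a group of 12 heavy atoms (7 carbon, 1 nitrogen, 4 oxygen; one six-membered aromatic ring of carbon only) in place of a group of 12 heavy atoms (8 carbon, 2 nitrogen, 2 oxygen; one five-membered aromatic ring with 2 hetero atoms, one six-membered aromatic ring of carbon only), on a saturated chain carbon bound to an amine nitrogen in a ring. Within the data shown here, no measured pair shows this kind of change, so its effect in this assay is an open question. A weaker compound is expected, since the group that leaves carries the fused two-ring system and the group that enters does not; the step from compound 1 to compound 3 is expected to be a 3.2-fold higher number from compound 1 to compound 3 (0.50 log units; beyond the scatter), beyond the scatter. Compound 3 is therefore estimated at 1200 nM, within 400 nM to 4000 nM.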

Compound 3, half-maximal effective concentration: 520 nM
The estimate for compound 3 lay 2.3-fold (0.36 log units) above the measured number; the measured number falls inside the stated range.
By their numbers in this assay, from the lowest: compounds 1 and 3 (each within the scatter of the next); then compound 2.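

In this assay the switch to the 4-carboxy-2-nitrophenyl group gives a 1.4-fold higher number from compound 1 to compound 3 (0.14 log units; within the scatter) and so leaves the number unchanged within the usual scatter. At this place, on a saturated chain carbon bound to an amine nitrogen in a ring, a single six-membered aromatic ring of carbon only can thus stand in for the pair of a five-membered and a six-membered aromatic ring without a clear loss. No outside measurement helps to explain why the two groups match.

Both groups carry a carboxylic acid, so these compounds do not show whether that acid is needed, or how a methyl ester or a primary amide would behave in its place. The part played by the nitro group is open as well, since a comparison with a plain hydrogen or a nitrile at that spot would be needed to show it.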